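A Missing Hydroxy Result and an Estimate

The compounds below may be only part of what the source reports. "The series", "measured", "known", "first", "only" and "open" are said of these compounds alone.

Measured so far in a functional assay on CNE-2 cells (Homo sapiens) for cytotoxicity, read by sulforhodamine B assay, with a stated time of 48 h; a lower number here means a stronger inhibitor, a higher number a weaker inhibitor:
Compound 1 `COc1ccc(/C=C/C(=O)c2ccc(N)c(-c3ccc(F)cc3)c2)cc1` gives 1600 nM
Compound 2 `COc1cccc(/C=C/C(=O)c2cccc(-c3cccc(F)c3)c2)c1OC` gives 10000 nM
Compound 3 `COc1ccc(/C=C/C(=O)c2cccc(-c3cccc(F)c3)c2)cc1O` gives "not determined" (no result reported)

Compound 3 has no single number, so it holds no place on the scale of this assay and offers no value to start from. The structural change is hydrogen in place of hydroxy on an aromatic carbon and it amounts to hydrogen in place of hydroxy on an aromatic carbon, ortho to a methoxy group. The result is compound 4 `COc1ccc(/C=C/C(=O)c2cccc(-c3cccc(F)c3)c2)cc1` and it has not yet been measured. Going by the values given here, no two measured compounds differ in only one place, so no step of this kind has been seen. No step beyond the scatter is expected for this change in this assay, although the missing result for compound 3 leaves that expectation untestable. Among the compounds with values here, the only guide is compound 1 at 1600 nM and compound 2 at 10000 nM as two reference points. Compound 4 is estimated at 5000 nM with an expected range from 1500 nM to 20000 nM when measured.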

Compound 4, half-maximal inhibitory concentration: 740 nM
For compound 4 the middle estimate is 6.8-fold (0.83 log units) above the measured one; the measured number lies below the stated range.
By their numbers in this assay, from the lowest: compound 4; then compound 1; then compound 2.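

Compound 3 has no single number in this assay, and compound 1 and compound 2 each differ from compound 4 in more than one place, so no new step can be read. Whether hydrogen in place of hydroxy shifts the result in this assay stays open, and no measured evidence explains the result for compound 4.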